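This account rests on a few compounds, and the source may have more. Where it says the series, first, only, none or still open, it means among the compounds named here.

Measured in a functional assay on NCI-H23 cells (Homo sapiens) for inhibition, read by sulforhodamine B assay, with a stated time of 48 h; a higher number here means a weaker inhibitor of growth, a lower number a stronger inhibitor of growth:
compound 1 `CCOC(=O)C(=Cc1c(-c2ccccc2)[nH]c2ccccc12)C(=O)OCC` gives 2900 nM
compound 2 `COc1ccc(-c2[nH]c3ccc(OC)cc3c2/C=C(\C#N)S(=O)(=O)c2ccccc2)cc1` gives 946 nM
compound 3 `CC(=O)/C(=C\c1c(-c2ccccc2)[nH]c2ccccc12)S(=O)(=O)c1ccccc1` gives 1600 nM

Compound 3 sits within the scatter of both other numbers in this assay: its gap to compound 2 and its gap to compound 1 each fall inside the usual spread of repeated measurements, so no order among the three can be read from these values. Compound 4 `O=C(/C(=C\c1c(-c2ccccc2)[nH]c2ccccc12)S(=O)(=O)c1ccccc1)c1ccccc1` differs from compound 3 by phenyl in place of methyl on a carbonyl carbon, acetyl to benzoyl. Among the measured compounds shown here, no measured pair shows this change, so its effect in this assay is not known from the series; the expectation is a step not beyond the scatter, in no firm direction. Compound 4 is therefore estimated at 1500 nM, with a range from 500 nM to 4500 nM, an expected step of a 1.1-fold lower number from compound 3 to compound 4 (0.03 log units; within the scatter) that stays inside the scatter.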

Compound 4, concentration for 50% growth inhibition: 9600 nM
Beside the measured number, compound 4's estimate is 6.4-fold (0.81 log units) below it; measured number above the stated range.
By their numbers in this assay, from the lowest: compounds 2, 3 and 1 (each within the scatter of the next, the first and the last beyond it); then compound 4.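

Among the compounds shown here, the only one-place pair shows that the group on the carbonyl carbon matters: in this assay phenyl in place of methyl gives a 6.0-fold higher number from compound 3 to compound 4 (0.78 log units; beyond the scatter) and so moves the number beyond the scatter. Compounds 1, 2 and 3 could not show this, as none of them differ in one place. Nothing at hand accounts for the size of this step.

Going by these compounds, whether ethyl or a longer chain on this carbonyl carbon stays close to compound 3 remains open. So does the outcome with an amine or a carboxylic acid there.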